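Compound 3 to compound 4: exchanging the methylamino group

The source may hold more compounds than are shown below. What is called first, only, known or untested is meant among the compounds shown, and "the series" means these compounds.

In a functional assay on L02 cells (Homo sapiens) for inhibition, read by Griess assay, with stated times of 1 h and 24 h (on this read-out lower numbers stand for stronger inhibition and higher numbers for weaker inhibition), compound 3 `CNc1nc(/C=C/c2ccco2)nc2ccsc12` gives 811000 nM. Compound 1 `CCCc1nn(C)c2c(NCc3ccc(F)cc3)nc(/C=C/c3cccnc3)nc12` gives 940000 nM, which lies within the scatter of compound 3. Compound 2 `CNc1nc(/C=C/c2ccccc2)nc2ccsc12` reads > 1000000 nM, which is a limit of the assay and not a number.

Compound 4 `CN1CCN(c2nc(/C=C/c3ccco3)nc3ccsc23)CC1` differs from compound 3 in one place: 4-methylpiperazin-1-yl in place of methylamino on an aromatic carbon. This puts 4-methylpiperazin-1-yl in place of methylamino on an aromatic carbon.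

Among the measured compounds shown here, the only measured step is an at least 1.2-fold lower number from compound 2 to compound 3 (0.09 log units; that floor lies within the scatter). It concerns furan-2-yl in place of phenyl on the chain, not the place changed here, and its floor lies within the scatter. For the measured compounds named here, no measured step therefore gives a size for this exchange, and no direction can be drawn from the data. The expectation in this assay is no step beyond the scatter, so the working anchor is compound 3 at 811000 nM. Also to be kept in view is the limit of > 1000000 nM in this assay, at which 1 of the 3 values shown sits, so a report of compound 4 as a limit is possible.

The expected change is a 1.2-fold lower number from compound 3 to compound 4 (0.06 log units; within the scatter), which stays within the scatter.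

For compound 4 the estimated value is 700000 nM, with an expected range of 200000 nM to 1300000 nM.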

Compound 4, half-maximal inhibitory concentration: > 1000000 nM
Compound 4: only a limit was reported; the forecaster's own chance of this, stated with the estimate: 30%; middle value at least 1.4-fold (0.15 log units) from the limit.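

In this assay, putting 4-methylpiperazin-1-yl in place of methylamino on the aromatic carbon next to the ring nitrogen gives an at least 1.2-fold higher number from compound 3 to compound 4 (0.09 log units; that floor lies within the scatter). Among the compounds shown here, this is the first reading at this place, and it shows that exchanging the open methylamino group for a six-membered non-aromatic ring brings no lower number, while the true size of the step cannot be read. The value of compound 4 is a limit and not a number, the second of its kind in the series: the limit of > 1000000 nM in this assay, at which 2 of the 4 values shown sit.

Going by these compounds, how far compound 4 truly lies from compound 3 stays open, as does whether any group at this place can move the number beyond the scatter. Also open, on these data alone, is what a primary amino group, dimethylamino or morpholin-4-yl would give on the same aromatic carbon with the furan-2-yl chain kept, and whether any of them would give a number that can be read rather than a limit.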